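The source may report more compounds than this note shows. Statements on the series, on what has been measured and on what is new or still open speak of the compounds shown alone.

Among the measured compounds shown here, compound 2 `O=c1[nH]cc(S(=O)(=O)Nc2ccc(-c3cn(-c4ccccc4)nn3)cc2)c(=O)[nH]1` is the only member of the series with a number in a functional assay on HepG2 cells (Homo sapiens) for antiproliferative activity, read by MTT assay, with a stated time of 24 h; a higher number here means a weaker inhibitor, a lower number a stronger inhibitor; there compound 2 gives 18000 nM. Compound 1 `O=c1[nH]cc(S(=O)(=O)Nc2ccccc2-c2cn(-c3ccc(F)cc3)nn2)c(=O)[nH]1` reaches only a limit of the assay, > 20000 nM, and so sits at the limit of > 20000 nM in this assay, at which 1 of the 2 values shown sits. Compound 3 `Cc1ccccc1-n1cc(-c2ccc(NS(=O)(=O)c3c[nH]c(=O)[nH]c3=O)cc2)nn1` is not yet measured. It differs from compound 2 by methyl in place of hydrogen on an aromatic carbon. No step between measured compounds is shown, so the series itself gives no direction for this change. The step from compound 2 to compound 3 is expected to stay within the usual scatter: a 1.2-fold lower number from compound 2 to compound 3 (0.08 log units; within the scatter). Compound 3 is therefore estimated at 15000 nM, with a range from 6000 nM to 40000 nM.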

Compound 3, half-maximal inhibitory concentration: 14500 nM
Estimate against measurement, compound 3: 1.0-fold (0.01 log units) above; low and high end bracket the measured number.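

In this assay, among the compounds shown here, phenyl to 2-methylphenyl gives the first readable step, a 1.2-fold lower number from compound 2 to compound 3 (0.09 log units; within the scatter). Methyl on this aromatic carbon, ortho to a large group, therefore does not separate compound 3 from compound 2. Both numbers lie close to the assay's limit, so there is little room to read any weakening: the limit of > 20000 nM in this assay, at which 1 of the 3 values shown sits.

From the compounds shown here alone, whether an amine, a carboxylic acid or a longer chain at this place would move the number beyond the scatter remains open. For the compounds shown here, compound 1 differs from compound 2 in more than one place, so no step to it can be read.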